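Alkyl versus alkoxy at the fused-ring carbon: lipophilicity

The compounds below may be only part of what the source reports. "The series", "measured", "known", "first", "only" and "open" are said of these compounds alone.

Measured compounds:
compound 1 `CCCCc1ccc2[nH]c(-c3ccc(OC)cc3)c(C3=C(Br)C(=O)NC3=O)c2c1` gives 3.83;
compound 2 `CCOc1ccc2[nH]c(-c3cccc(OC)c3)c(C3=C(Br)C(=O)NC3=O)c2c1` gives 2.97;
compound 3 `CCCCCCOc1ccc2[nH]c(-c3cccc(OC)c3)c(C3=C(Br)C(=O)NC3=O)c2c1` gives 3.92.

In a physicochemical assay for lipophilicity (on this read-out higher numbers stand for higher lipophilicity and lower numbers for lower lipophilicity), compound 3 stands highest of the three numbers shown; compound 1 lies within the scatter of it, and compound 2 lies beyond the scatter below it. Among the compounds with values here, the one step that bears on the change is a number 0.95 log units higher from compound 2 to compound 3 (beyond the scatter), a modest rise on lengthening the alkoxy chain.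

Compound 4 `CCCCc1ccc2[nH]c(-c3cccc(OC)c3)c(C3=C(Br)C(=O)NC3=O)c2c1` is reached from compound 3 by butyl in place of hexyloxy on an aromatic carbon. Compound 1 carries the same butyl group yet differs from compound 4 in a second place, so it serves only as a rough guide. Removing the oxygen and two chain carbons is expected to lower the number slightly, by about a number 0.32 log units lower from compound 3 to compound 4 (beyond the scatter), so compound 4 is estimated at 3.6 (range 3.2 to 4).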

Compound 4, partition coefficient: 3.81
Compound 4: middle estimate off by 0.21 log units, on the low side, and the stated range covers the measured number.
By their numbers in this assay, from the lowest: compound 2; then compounds 4, 1 and 3 (each within the scatter of the next).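

In this assay butyl in place of hexyloxy on the aromatic carbon gives a number 0.11 log units lower from compound 3 to compound 4 (within the scatter) and leaves these two groups unseparated. Butyl in place of ethoxy gives a number 0.84 log units higher from compound 2 to compound 4 (beyond the scatter) and so, of the three groups at this position, only the ethoxy of compound 2 stands apart. With butyl held, 3-methoxyphenyl in place of 4-methoxyphenyl gives a number 0.02 log units lower from compound 1 to compound 4 (within the scatter) and does not separate that pair.

Open, on these data alone, is where an amine, a carboxylic acid or a longer chain on this aromatic carbon would fall in this assay relative to these compounds. Nothing at hand accounts for these numbers.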